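Removing One Methoxy Group from Compound 1

The compounds below may be only part of what the source reports. "The series", "measured", "known", "first", "only" and "open" are said of these compounds alone.

Values so far in a functional assay on DU-145 cells (Homo sapiens) for antiproliferative activity, read by sulforhodamine B assay, with a stated time of 48 h; on this read-out higher numbers stand for weaker inhibition and lower numbers for stronger inhibition (lower means stronger inhibition):
- Compound 1 `COc1cc(NS(=O)(=O)c2ccc(N3CCNC3=O)cc2)cc(OC)c1OC` gives 51 nM
- Compound 2 `Cc1cc(C)cc(NS(=O)(=O)c2ccc(N3CCNC3=O)cc2)c1` gives 430 nM

Compound 1 holds the lower of these two numbers, and its gap to compound 2 lies beyond the usual scatter. Compound 3 `COc1cc(NS(=O)(=O)c2ccc(N3CCNC3=O)cc2)cc(OC)c1` has not yet been measured. It carries hydrogen in place of methoxy on an aromatic carbon, ortho to two methoxy groups and para to a large group (hydrogen in place of methoxy on an aromatic carbon). For the measured compounds named here, no measured pair shows this change, so any forecast is uncertain. Going by the values given here, the only guide is that compound 2 (430 nM) sits well above compound 1 (51 nM), so a low number like that of compound 1 cannot be taken for granted. In this assay the expected move is upward, towards weaker inhibition and beyond the scatter (a 4.9-fold higher number from compound 1 to compound 3 (0.69 log units; beyond the scatter)). Compound 3 is estimated at 250 nM (expected range 80 nM to 800 nM).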

Compound 3, half-maximal inhibitory concentration: 700 nM
Beside the measured number, compound 3's estimate is 2.8-fold (0.45 log units) below it; low and high end bracket the measured number.
By their numbers in this assay, from the lowest: compound 1; then compounds 2 and 3 (each within the scatter of the next).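

In this assay, taking one methoxy group off the aromatic carbon para to a large group and leaving hydrogen there gives a 14-fold higher number from compound 1 to compound 3 (1.14 log units; beyond the scatter). For the compounds shown here, this is the first pair of compounds that differ in this one place, and it shows that this single methoxy group counts for much of the strong inhibition seen with compound 1. Nothing available here explains why the step is this large.

Going by these compounds, it remains open whether a different group on this carbon, such as a hydroxyl, an ethoxy group or an amine, would bring the number back towards that of compound 1. The compounds shown also leave open whether removing either of the other two methoxy groups would produce a step of similar size.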